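A few compounds are considered here, and "the series" means these few. Any claim that something is new, unique, unknown or untested is made for them only; others in the source may bear on it.

Of the compounds shown here, three have so far been measured in a functional assay on MDA-MB-231 cells (Homo sapiens) for cytotoxicity, read by sulforhodamine B assay, with a stated time of 48 h; a lower number here means a stronger inhibitor of growth, a higher number a weaker inhibitor of growth. Compound 1 `CN(C)CN1C(=O)C(=O)c2c(Br)cccc21` gives 93700 nM. Compound 2 `O=C1C(=O)N(CN2CCCCC2)c2cccc(Br)c21` carries piperidin-1-yl in place of dimethylamino on a saturated chain carbon bound to an amide-type nitrogen in a ring; in this assay compound 2 gives 30200 nM, which makes a step of a 3.1-fold lower number from compound 1 to compound 2 (0.49 log units; beyond the scatter). Compound 3 `Cc1ccc2nc(/N=C3\C(=O)N(CN(C)C)c4cccc(Cl)c43)sc2c1` is built on another core, and the difference between the core of compound 1 and the core of compound 3 is not broken down here. In this assay compound 3 gives 10900 nM, the lowest of the three numbers.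

Compound 4 `Cc1ccc2nc(/N=C3\C(=O)N(CN4CCCCC4)c4cccc(Cl)c43)sc2c1` has not yet been measured. It differs from compound 3 by piperidin-1-yl in place of dimethylamino on a saturated chain carbon bound to an amide-type nitrogen in a ring, the same kind of change as from compound 1 to compound 2, now made on the core of compound 3. Among the compounds with values here, because the earlier change gave a 3.1-fold lower number from compound 1 to compound 2 (0.49 log units; beyond the scatter), a step of roughly that size is expected here as well, though with only one earlier example and a different core the size is uncertain. The expected step is a 3.0-fold lower number from compound 3 to compound 4 (0.48 log units; beyond the scatter). Compound 4 is estimated at 3600 nM in this assay, with a likely range from 1500 nM to 9000 nM.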

Compound 4, concentration for 50% growth inhibition: 55800 nM
Estimate against measurement, compound 4: 16-fold (1.19 log units) below; measured number above the stated range.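

On the core of compound 3, putting piperidin-1-yl in place of dimethylamino gives a 5.1-fold higher number from compound 3 to compound 4 (0.71 log units; beyond the scatter) in this assay, so the change runs the opposite way from the earlier case, and the two steps disagree: the same change on two cores in this assay, a 3.1-fold lower number (0.49 log units; beyond the scatter) from compound 1 to compound 2 and a 5.1-fold higher number (0.71 log units; beyond the scatter) from compound 3 to compound 4, 16-fold (1.20 log units) apart, beyond the scatter of two such steps. For these two pairs, then, the step measured on one core is a poor guide to the same change on the other, and its direction cannot simply be carried across. This does not show which feature of the cores reverses the step, as they differ in more than one place, and one pair per core gives no general rule for the series.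

On these data alone, it remains open whether other amines on the same chain carbon, such as morpholin-4-yl or pyrrolidin-1-yl, would follow the trend of the first pair or the second on either core. Also open, as far as these compounds go, is how dimethylamino and piperidin-1-yl would compare on a core like that of compound 3 but carrying bromine instead of chlorine.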